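The source may report more compounds than this note shows. Statements on the series, on what has been measured and on what is new or still open speak of the compounds shown alone.

Measured so far in a physicochemical assay for solubility, read by HPLC, measured as kinetic solubility, at pH 4; a lower number here means a less soluble compound, a higher number a more soluble compound:
- Compound 1 `FC(F)(F)c1c(CN2CCC(c3ccccc3)CC2)ccn2c(CC3CC3)nnc12`: > 100000 nM
- Compound 2 `Fc1ccc(OC2CCN(Cc3ccn4c(CC5CC5)nnc4c3C(F)(F)F)CC2)c(F)c1`: > 100000 nM

Both entries are limits of the assay and not numbers. Compound 2 stands at > 100000 nM, which is a limit. Compound 1 also gives only a limit, so the whole record consists of the limit of > 100000 nM in this assay, at which 2 of the 2 values shown sit.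

Compound 3 `Fc1ccc(COC2CCN(Cc3ccn4c(CC5CC5)nnc4c3C(F)(F)F)CC2)c(F)c1` keeps the shared core of compound 2 and alters one group: 2,4-difluorobenzyl in place of 2,4-difluorophenyl on an oxygen on a saturated carbon. Cut one bond further out, the same difference reads 2,4-difluorophenoxy to (2,4-difluorobenzyl)oxy.

For the measured compounds named here, only one measured step bears on this change: a step that the two limits leave unreadable from compound 1 to compound 2. Going by the values given here, it offers no size to carry over, and no measured step shows what the new group does. With compound 2 at the limit of > 100000 nM, no step beyond the scatter is expected in this assay, and no direction can be assigned. The estimated step is a number no higher from compound 2 to compound 3 (the limit leaves the size open). For compound 3 the expected value is 100000 nM, with an estimated range of 50000 nM to 150000 nM. A report of the limit alone is the likeliest outcome.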

Compound 3, solubility: > 100000 nM
Compound 3: a limit, no number; the forecaster's own chance of this, stated with the estimate: 85%; the middle value sits exactly at the limit.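

In this assay compound 3 gives > 100000 nM as a limit and not a number, so the steps joining compound 3 to compound 1 and compound 2 cannot be read. The record holds a single reading: the limit of > 100000 nM in this assay, at which 3 of the 3 values shown sit.

The compounds shown leave open what number any of them would give, and so what 2,4-difluorobenzyl does in place of 2,4-difluorophenyl.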